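This account rests on a few compounds, and the source may have more. Where it says the series, first, only, none or still open, it means among the compounds named here.

In an ADME assay on microsomes from liver (Mus musculus) for metabolic stability, read by HPLC, using NADPH, with a stated time of 60 min, tested at 1 uM, in the presence of a further agent that is not named here (a higher number here means that the compound lasts longer, a lower number that the compound disappears faster), compound 1 (`O=C(NNS(=O)(=O)c1ccccc1F)c1cc(F)cc(-c2ccccn2)c1`) gives 0.217 h, while compound 2 (`Cc1cc(-c2ncccn2)cc(C(=O)NNS(=O)(=O)c2ccccc2)c1F`) gives 0.1 h. Compound 2 therefore holds the lower of the two numbers, and its gap to compound 1 lies beyond the usual scatter of repeated measurements. The next structure, compound 3 (`Cc1cc(-n2cccn2)cc(C(=O)NNS(=O)(=O)c2ccccc2)c1F`), keeps everything in compound 2 except one group: 1H-pyrazol-1-yl stands in place of pyrimidin-2-yl on an aromatic carbon (1H-pyrazol-1-yl in place of pyrimidin-2-yl on an aromatic carbon). A six-membered aromatic ring is thus exchanged for a five-membered one, at the same place on the ring of carbon only, para to the fluoro group. For the measured compounds named here, no measured pair shows this exchange on its own, so the best guide is compound 2 at 0.1 h, the only close relative. In this assay, no change beyond the scatter is expected, with at most a slight lean upward. The estimated change is a 1.2-fold higher number from compound 2 to compound 3 (0.08 log units; within the scatter). For compound 3, the expected half-life is 0.12 h, with an estimated range of 0.06 h to 0.25 h.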

Compound 3, half-life in the Mus musculus assay: 0.05 h
Compound 3: the middle estimate sits 2.4-fold (0.38 log units) above what was measured; the measured number lies below the stated range.
By their numbers in the Mus musculus assay, from the lowest: compounds 3 and 2 (each within the scatter of the next); then compound 1.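

In the Mus musculus assay, putting 1H-pyrazol-1-yl in place of pyrimidin-2-yl gives a 2.0-fold lower number from compound 2 to compound 3 (0.30 log units; within the scatter), so this first direct test of the exchange does not separate the two rings on half-life. The same exchange does separate them in a physicochemical assay for solubility, read by nephelometry, measured as kinetic solubility, at pH 2 (on this read-out lower numbers stand for lower solubility and higher numbers for higher solubility), where compound 2 gives 50 ug/mL and compound 3 gives 6.3 ug/mL, and the five-membered ring goes with clearly poorer solubility than the six-membered ring at this position: the measured solubility of compound 2, 50 ug/mL, and of compound 3, 6.3 ug/mL, a 7.9-fold lower number (0.90 log units; beyond the scatter) Taken together, the pair shows that a change too small to read in one assay can still be large in another, though this rests on a single exchange at one place, para to a fluoro group, on one core.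

The compounds shown leave open how a group of another kind at this place, such as an amine or a carboxylic acid, would read in the Mus musculus assay and in the physicochemical assay. They also leave open whether the exchange of these two rings would read the same way on the core of compound 1.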